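This account rests on a few compounds, and the source may have more. Where it says the series, first, only, none or still open, it means among the compounds named here.

Compound 1 `Cc1c(C(=O)N=C(N)N)cc(S(C)(=O)=O)c(Cl)c1[N+](=O)[O-]`: 44 nM
Compound 2 `Cc1cc(C2CCCCC2)c(S(C)(=O)=O)cc1C(=O)N=C(N)N`: 22 nM

Of the compounds shown here, two sharing the same acylguanidine-bearing core have been measured in a functional assay for inhibition of sodium/hydrogen exchanger (Oryctolagus cuniculus); on this read-out higher numbers stand for weaker inhibition and lower numbers for stronger inhibition. Compound 1 `Cc1c(C(=O)N=C(N)N)cc(S(C)(=O)=O)c(Cl)c1[N+](=O)[O-]` gives 44 nM, and compound 2 `Cc1cc(C2CCCCC2)c(S(C)(=O)=O)cc1C(=O)N=C(N)N` gives 22 nM. On the numbers shown, compound 2 stands at the lowest of the two, yet compound 1 sits within the usual scatter of it, so the two are not told apart by this assay.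

Compound 3 `Cc1cc(Sc2ccccc2Cl)c(S(C)(=O)=O)cc1C(=O)N=C(N)N` has not yet been measured. It differs from compound 2 in one place: (2-chlorophenyl)sulfanyl in place of cyclohexyl on an aromatic carbon. The group that enters carries one hydrogen-bond acceptor where the cyclohexyl carried none, and it is an aromatic ring in place of a non-aromatic one, joined through sulfur.

Among the measured compounds shown here, no step between measured compounds is available that would show how this assay responds to a change of this kind. The expected step from compound 2 to compound 3 is therefore small, a 1.4-fold higher number from compound 2 to compound 3 (0.13 log units; within the scatter), and may not reach beyond the scatter in either direction. Compound 3 is estimated at 30 nM, with a range from 8 nM to 120 nM.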

Compound 3, half-maximal inhibitory concentration: 14 nM
The estimate for compound 3 lay 2.1-fold (0.33 log units) above the measured number; measured number inside the range.
By their numbers in this assay, from the lowest: compounds 3, 2 and 1 (each within the scatter of the next, the first and the last beyond it).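

The position on the aromatic carbon ortho to the methylsulfonyl group and para to the group of 6 heavy atoms accepts two very different substituents without a change that this assay can resolve. Exchanging the non-aromatic cyclohexyl ring for (2-chlorophenyl)sulfanyl, an aromatic ring joined through sulfur and carrying one hydrogen-bond acceptor, gives a 1.6-fold lower number from compound 2 to compound 3 (0.20 log units; within the scatter) and so stays inside the scatter, which means that neither group can be ranked over the other here. Nothing shown bears on why this exchange leaves the number so little moved.

As far as these compounds go, a single step cannot separate what the sulfur, the chlorine and the aromatic ring each contribute, so it remains open how a plain phenylsulfanyl group, a 2-chlorophenoxy group or a directly attached phenyl ring would read at this carbon. From the compounds shown here alone, it is equally open whether this tolerance extends to an amine such as piperidine or to a carboxylic acid, and whether the same exchange would behave alike on the core of compound 1.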